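The source may report more compounds than this note shows. Statements on the series, on what has been measured and on what is new or still open speak of the compounds shown alone.

Measured so far:
compound 1 `O=C(N/N=C/C1=Cc2ccccc2OC1)c1ccc(Cl)cc1` — "not determined" (no result reported)
compound 2 `CC1Oc2ccccc2C=C1/C=N/NC(=O)c1ccco1` — 21200 nM
compound 3 `O=C(N/N=C/C1=Cc2ccccc2OC1c1ccccc1)c1ccc(Cl)cc1` — 13200 nM

In a toxicity assay on HEK-293T cells (Homo sapiens) for cytotoxicity, read by MTT assay, with a stated time of 72 h (on this read-out lower numbers stand for stronger inhibition and higher numbers for weaker inhibition), compound 3 holds the lower of the two numbers, with compound 2 the nearer neighbour at a slightly higher value, a gap that lies within the scatter. Compound 1 has no result in this assay. Compound 4 `O=C(N/N=C/C1=Cc2ccccc2OC1c1ccccc1)c1ccco1` differs from compound 3 by a single exchange: furan-2-yl in place of 4-chlorophenyl on a carbonyl carbon. Within the data shown here, no measured pair shows this exchange on its own, so the size of the step can only be expected. The pairing of a furan-2-yl with a value in the same region for compound 2 suggests a small move toward a higher number, no greater than the scatter. For compound 4 the estimate is 18000 nM, in the range 7000 nM to 45000 nM, meaning an expected step of a 1.4-fold higher number from compound 3 to compound 4 (0.13 log units; within the scatter).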

Compound 4, half-maximal inhibitory concentration: 11900 nM
Compound 4: middle estimate off by 1.5-fold (0.18 log units), on the high side; measured number inside the range.
By their numbers in this assay, from the lowest: compounds 4, 3 and 2 (each within the scatter of the next).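

Among these compounds, on the carbonyl carbon, furan-2-yl and 4-chlorophenyl cannot be told apart in this assay (a 1.1-fold lower number from compound 3 to compound 4 (0.05 log units; within the scatter)), so this exchange, seen here for the first time as a single change, leaves the number within the scatter. On the saturated ring carbon, phenyl in place of methyl also stays within the scatter (a 1.8-fold lower number from compound 2 to compound 4 (0.25 log units; within the scatter)). Nothing available explains these results.

On these data alone, what a piperidine amine or a carboxylic acid on the carbonyl carbon would give remains open. So does the outcome of a longer alkyl chain on the saturated ring carbon.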